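This account rests on a few compounds, and the source may have more. Where it says the series, first, only, none or still open, it means among the compounds named here.

In a functional assay on aorta (Rattus norvegicus) for inhibition (on this read-out lower numbers stand for an effect already at smaller amounts and higher numbers for an effect only at larger amounts of compound), compound 1 `CCCNC1=NS(=O)(=O)c2cccc(Cl)c2N1` gives 180000 nM. Compound 2 `CCCNC1=NS(=O)(=O)c2c(Cl)cccc2N1` gives > 300000 nM, which is a limit of the assay and not a number. Within the data shown here, compound 3 `CCNC1=NS(=O)(=O)c2cc(Cl)ccc2N1` gives 39900 nM, the lowest of the numbers so far and lower than that of compound 1 by more than the usual scatter.

Compound 4 `CCCNC1=NS(=O)(=O)c2cc(Cl)ccc2N1` has not yet been measured. It extends the ethylamino chain of compound 3 to propylamino: methyl in place of hydrogen on a saturated chain carbon, two bonds along the chain from an amine nitrogen, with methyl in place of hydrogen on a saturated chain carbon, two bonds along the chain from an amine nitrogen. Among the measured compounds shown here, no measured pair isolates this change, although compound 1 and compound 2 also carry the propylamino chain, on cores that differ from that of compound 4. In this assay, a small step to a slightly lower number is expected, hardly beyond the scatter, so the value of compound 3 at 39900 nM serves as the anchor. The expected change is a 1.4-fold lower number from compound 3 to compound 4 (0.15 log units; within the scatter). For compound 4, the estimated value is 28000 nM, with an expected range of 9000 nM to 85000 nM.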

Compound 4, half-maximal effective concentration: 55500 nM
Compound 4: the middle estimate sits 2.0-fold (0.30 log units) below what was measured, and the stated range covers the measured number.
By their numbers in this assay, from the lowest: compounds 3 and 4 (each within the scatter of the next); then compound 1. At a limit, above all of these: compound 2.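

In this assay, going from ethylamino to propylamino on a shared core gives a step that stays within the scatter (a 1.4-fold higher number from compound 3 to compound 4 (0.14 log units; within the scatter)), so the two chains cannot be told apart on this read-out. The earlier compounds shown here could not show this, as none of them formed a pair differing only in the chain. This is a single pair on a single core, so it says only that adding this one methyl at this place leaves no readable mark here, and no measurement shown gives a reason for that.

From the compounds shown here alone, it remains open whether a shorter methylamino chain or a longer butylamino chain would move the number beyond the scatter. A chain ending in an amine or a carboxylic acid is equally untested by the compounds shown here.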